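This account rests on a few compounds, and the source may have more. Where it says the series, first, only, none or still open, it means among the compounds named here.

Of the compounds shown here, three of one shared core have been measured in a functional assay on PC-3 cells (Homo sapiens) for inhibition, read by MTT assay, with a stated time of 48 h; on this read-out higher numbers stand for weaker inhibition and lower numbers for stronger inhibition. Compound 1 `C=C1CC[C@@H]2[C@](C)(CO)[C@H](O)CC[C@@]2(C)[C@@H]1CC(Sc1ncccn1)C1=CCOC1=O` gives 7000 nM. Among the compounds with values here, compound 2 `C=C1CC[C@@H]2[C@](C)(CO)[C@H](O)CC[C@@]2(C)[C@@H]1CC(Sc1nccs1)C1=CCOC1=O` gives 14000 nM; the single measured step, a 2.0-fold higher number from compound 1 to compound 2 (0.30 log units; within the scatter), exchanges the heteroaryl on the sulfur and stays within the scatter. Compound 3 `C=C1CC[C@@H]2[C@](C)(CO)[C@H](O)CC[C@@]2(C)[C@@H]1C/C=C1/C(=O)OC[C@H]1OC(=O)CSc1ccc(C)cc1` gives 27000 nM, the highest of the three numbers: its gap to compound 2 lies within the scatter, while its gap to compound 1 lies beyond it, so compound 3 inhibits less strongly than compound 1.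

Compound 4 `C=C1CC[C@@H]2[C@](C)(CO)[C@H](O)CC[C@@]2(C)[C@@H]1C/C=C1/C(=O)OC[C@H]1OC(=O)CCCSc1ccc([N+](=O)[O-])cc1` differs from compound 3 in one place: 2-((4-nitrophenyl)sulfanyl)ethyl in place of (4-methylphenyl)sulfanyl on a saturated chain carbon bound to a carbonyl carbon. Within the data shown here, the only measured step, from compound 1 to compound 2, concerns a different part of the molecule, a heteroaryl on a sulfur, and no measured pair exchanges the group on the saturated chain carbon bound to a carbonyl carbon. That step was small and within the scatter, and nothing here points to a large movement in either direction for this change. The step from compound 3 to compound 4 is therefore expected to be a 1.1-fold higher number from compound 3 to compound 4 (0.05 log units; within the scatter), not beyond the scatter. Compound 4 is estimated at 30000 nM, with a range from 10000 nM to 90000 nM.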

Compound 4, half-maximal inhibitory concentration: 17000 nM
For compound 4 the middle estimate is 1.8-fold (0.25 log units) above the measured one, and the stated range covers the measured number.
By their numbers in this assay, from the lowest: compounds 1, 2, 4 and 3 (each within the scatter of the next, the first and the last beyond it).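

In this assay, within the data shown here, the first exchange at the saturated chain carbon bound to a carbonyl carbon gives a 1.6-fold lower number from compound 3 to compound 4 (0.20 log units; within the scatter), so compound 3 and compound 4 cannot be told apart on this read-out. The entering 2-((4-nitrophenyl)sulfanyl)ethyl has 12 heavy atoms and 3 hydrogen-bond acceptors, whereas the leaving (4-methylphenyl)sulfanyl has 8 heavy atoms and 1 hydrogen-bond acceptor, so at this position, for this one pair, a substantial change in the group leaves no readable difference in inhibition. No measured information is available that would explain this outcome or assign it to any part of the exchanged group.

Because this exchange alters the chain and the substituent on the aromatic ring together, the compounds shown leave open what each change does alone, which a 2-((4-methylphenyl)sulfanyl)ethyl group or a (4-nitrophenyl)sulfanyl group at the same carbon would separate. They also leave open whether an amine or a carboxylic acid on the aromatic ring in place of the nitro group would move the number beyond the scatter.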